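The source may report more compounds than this note shows. Statements on the series, on what has been measured and on what is new or still open speak of the compounds shown alone.

Of the compounds shown here, two share one core and have been tested in a functional assay on cardiac atrium (Cavia porcellus); on this read-out lower numbers stand for an effect already at smaller amounts and higher numbers for an effect only at larger amounts of compound. Compound 1, with the structure `COC(=O)C1=C(C)NC(C)=C(C(=O)OC)C1c1c(-c2cccnc2)nc2sc(C)cn12`, gives 12500 nM in this assay. Compound 2, with the structure `COC(=O)C1=C(C)NC(C)=C(C(=O)OC)C1c1c(-c2ccccn2)nc2sccn12`, gives 24400 nM in this assay. Compound 1 gives the smaller of these two numbers, but its gap to compound 2 lies within the usual scatter of repeated measurements, so the two cannot be told apart on this evidence. Among the compounds with values here, compound 2 also differs from compound 1 in more than one place, so no single step can be drawn between them.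

Compound 3, with the structure `COC(=O)C1=C(C)NC(C)=C(C(=O)OC)C1c1c(-c2ccncc2)nc2sc(C)cn12`, has not been measured in this assay. It differs from compound 1 in one place only: pyridin-4-yl in place of pyridin-3-yl on an aromatic carbon. Within the data shown here, no measured pair shows what such a change does here, so the expected step from compound 1 to compound 3 is a 1.0-fold lower number from compound 1 to compound 3 (0.02 log units; within the scatter), which is not beyond the scatter. Compound 3 is therefore estimated at 12000 nM in this assay, within a range from 5000 nM to 30000 nM.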

Compound 3, half-maximal effective concentration: 7490 nM
Compound 3: middle estimate off by 1.6-fold (0.20 log units), on the high side; the range from low to high includes it.
By their numbers in this assay, from the lowest: compounds 3, 1 and 2 (each within the scatter of the next, the first and the last beyond it).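

In this assay, within the data shown here, the first comparison at this spot that differs in one place only gives a 1.7-fold lower number from compound 1 to compound 3 (0.22 log units; within the scatter). Pyridin-3-yl and pyridin-4-yl hold the same atoms joined differently, and on this aromatic carbon the swap does not separate compound 1 from compound 3 on this evidence, so the two pyridine attachments cannot be told apart here. No independent measurement is at hand that would explain this result.

As far as these compounds go, both compounds in this comparison carry a pyridine ring at this spot, so it remains open whether a plain phenyl ring or an open-chain amine there would give a clearly different number. From the compounds shown here alone, it is also open whether the same swap would behave alike on a core with ethyl esters in place of the methyl esters.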